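The compounds below may be only part of what the source reports. "The series", "measured", "known", "first", "only" and "open" are said of these compounds alone.

Measured so far:
Compound 1, `COc1cc(NC(C)CCCNC(=O)NNC(=O)NCCCCCO)c2ncccc2c1`: 54%
Compound 2, `COc1ccc(/C(=N/NC(=O)NCCCC(C)Nc2cc(OC)cc3cccnc23)c2ccccc2)cc1`: 77%
Compound 3, `CCOC(=O)N(C)C(c1ccccc1)c1ccccc1`: "not active" (no number reported)

In a physicochemical assay for inhibition, read by spectrophotometry, tested at 100 uM (on this read-out lower numbers stand for less inhibition and higher numbers for more inhibition at the one concentration tested (going by the name of the read-out)), compound 1 gives 54%, the lower of the two numbers recorded in the series. Compound 2 gives 77%, a number that stands above that of compound 1 by more than the usual scatter. Compound 3 returns "not active" (no number reported), with no number reported. No pair among these three differs in one place only, so no single-point step is available to calibrate the next change.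

Compound 4, `COc1cc(NC(C)CCCNC(=O)NNC(=O)NC(CO)(CO)CO)c2ncccc2c1`, keeps the core of compound 1 and alters only the far end of the chain: 2-hydroxy-1,1-bis(hydroxymethyl)ethyl in place of 5-hydroxypentyl on an amide-type nitrogen. Going by the values given here, with no comparable step measured, the size and direction of the effect in this assay stay open; the working assumption is no shift beyond the scatter. The estimate for compound 4 is 48%, with a range from 25% to 70%. The expected step of a number 6 percentage points lower from compound 1 to compound 4 (within the scatter) is taken to lie within the usual scatter.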

Compound 4, a percentage reported as inhibition, at one concentration (the size of the read-out at that concentration, not a potency): 49%
Compound 4: the middle estimate sits 1 percentage points below what was measured, within the range that was stated.
By their numbers in this assay, from the lowest: compounds 4 and 1 (each within the scatter of the next); then compound 2.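

In this assay the series now has its first step at a single place: 2-hydroxy-1,1-bis(hydroxymethyl)ethyl in place of 5-hydroxypentyl on an amide-type nitrogen gives a number 5 percentage points lower from compound 1 to compound 4 (within the scatter). At this position, therefore, the exchange of one hydroxylated end group for the other does not separate compound 1 from compound 4 in this read-out, and the two are best treated as equivalent here. No measured evidence bears on this result.

Still open, on these data alone, is whether an amine, a carboxylic acid or a longer chain on the same nitrogen would move the number beyond the scatter. As far as these compounds go, the step also covers only these two end groups, so it remains open whether a single hydroxymethyl group or a morpholine ring in this place would read the same in this assay.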